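The source may report more compounds than this note shows. Statements on the series, on what has been measured and on what is new or still open speak of the compounds shown alone.

Measured so far:
compound 1, `COc1cc(Oc2cccc(Nc3ccccc3)c2)cc(OC)c1CNCCNC(C)=O`: 11900 nM
compound 2, `COc1cc(Oc2cccc(Nc3ccccc3)c2)cc(OC)c1CNC(C)C`: a limit of the assay, > 20000 nM
compound 3, `COc1ccc(CNCc2c(OC)cc(Oc3cccc(Nc4ccccc4)c3)cc2OC)cc1`: 6970 nM

The three share one core and differ only in the group carried on the amine nitrogen. In a functional assay on SW-620 cells (Homo sapiens) for inhibition, read by MTT assay, with a stated time of 72 h (a lower number here means a stronger inhibitor, a higher number a weaker inhibitor), compound 3 gives the lowest of the two numbers, but its nearest neighbour is close: a 1.7-fold lower number from compound 1 to compound 3 (0.23 log units; within the scatter). For compound 2 the assay reports only a limit, (the limit of > 20000 nM in this assay, at which 1 of the 3 values shown sits). Against that limit the step to compound 3 is clearer: an at least 2.8-fold lower number from compound 2 to compound 3 (0.45 log units; beyond the scatter).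

Compound 4, `COc1cc(Oc2cccc(Nc3ccccc3)c2)cc(OC)c1CNCc1ccc(O)cc1`, keeps the group on the amine nitrogen and alters only its far end: hydrogen in place of methyl on an oxygen on an aromatic ring. For the measured compounds named here, none of the measured steps touches this oxygen; each of them swaps the whole group on the amine nitrogen, a larger change than the one made here, and even those moved the numbers by a little. A step no larger than the scatter is therefore expected for compound 4: a 1.1-fold higher number from compound 3 to compound 4 (0.03 log units; within the scatter). The estimate for compound 4 is 7500 nM, expected to fall between 3000 nM and 18000 nM.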

Compound 4, half-maximal inhibitory concentration: 7940 nM
Compound 4: middle estimate off by 1.1-fold (0.02 log units), on the low side; the range from low to high includes it.
By their numbers in this assay, from the lowest: compounds 3, 4 and 1 (each within the scatter of the next). At a limit, above all of these: compound 2.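

In this assay, the methyl on the oxygen of the 4-methoxybenzyl group can give way to hydrogen with no step beyond the scatter: a 1.1-fold higher number from compound 3 to compound 4 (0.06 log units; within the scatter). The 4-hydroxybenzyl group also sits within the scatter of the 2-acetamidoethyl group, a 1.5-fold lower number from compound 1 to compound 4 (0.18 log units; within the scatter), while it keeps the clear separation from the isopropyl group, an at least 2.5-fold lower number from compound 2 to compound 4 (0.40 log units; beyond the scatter). That separation has only a floor, since compound 2 is a limit of the assay and not a number: the limit of > 20000 nM in this assay, at which 1 of the 4 values shown sits.

The compounds shown leave open whether a longer chain on this oxygen, such as ethyl, would give a step beyond the scatter. They also leave open what an amine or a carboxylic acid would do in place of the hydroxy group on the aromatic ring.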